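The compounds below may be only part of what the source reports. "The series", "measured", "known", "first", "only" and "open" are said of these compounds alone.

Measured in a functional assay on HL-60 cells (Homo sapiens) for inhibition, read by MTT assay, with a stated time of 72 h; a lower number here means a stronger inhibitor, a higher number a weaker inhibitor:
- compound 1 `Cc1nc(-c2ccccc2)c(C(=O)N2CCN(c3cccc(Cl)c3)CC2)o1`: 39.2 nM
- compound 2 `C=C(C)c1ccc(N2CCN(C(=O)c3oc(C)nc3-c3ccccc3)CC2)cc1`: "not active" (no number reported)
- compound 3 `CCOc1cccc(N2CCN(C(=O)c3oc(C)nc3-c3ccccc3)CC2)c1`: 151 nM

Compound 1 holds the lower of the two numbers, and compound 2 gives no number to compare. Compound 4 `Cc1nc(-c2cccc(OP(=O)(O)O)c2)c(C(=O)N2CCN(c3cccc(Cl)c3)CC2)o1` keeps the core of compound 1, with a group of 5 heavy atoms (4 oxygen, 1 phosphorus; no ring) in place of a hydrogen atom, on an aromatic carbon. Among the measured compounds shown here, no measured compound carries a change at that site. For the measured compounds named here, the only measured step, a 3.9-fold higher number from compound 1 to compound 3 (0.59 log units; beyond the scatter), is modest and concerns the chloro group, so it serves only as a loose guide to size. A modest step towards a higher number in this assay is therefore expected, with no change beyond the scatter still possible. The estimated step is a 2.6-fold higher number from compound 1 to compound 4 (0.41 log units; beyond the scatter). For compound 4 the estimate is 100 nM, with an expected range of 25 nM to 500 nM.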

Compound 4, half-maximal inhibitory concentration: > 1000 nM
Compound 4 gave a limit, no number (the forecaster's own chance of this, stated with the estimate: 10%); middle value at least 10-fold (1.00 log units) from the limit.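

Among the compounds shown here, compound 4 gives the only reading at this aromatic carbon, meta to a large group. In this assay, the group of 5 heavy atoms (4 oxygen, 1 phosphorus; no ring) in place of a hydrogen atom gives an at least 25-fold higher number from compound 1 to compound 4 (1.40 log units; beyond the scatter), so this site responds strongly to this change, more so than the chloro site in a 3.9-fold higher number from compound 1 to compound 3 (0.59 log units; beyond the scatter). The result for compound 4 is a limit, not a number: the limit of > 1000 nM in this assay, at which 1 of the 4 values shown sits.

Going by these compounds, it remains open whether an amine, a carboxylic acid or a methoxy group on this carbon would bring a step of similar size.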